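From a methoxyphenyl to a fluorophenyl amide cap

The compounds below may be only part of what the source reports. "The series", "measured", "known", "first", "only" and "open" are said of these compounds alone.

Two compounds have been measured in a functional assay on HCT-116 cells (Homo sapiens) for inhibition, read by colorimetric assay, with a stated time of 3 days; a higher number here means a weaker inhibitor, a lower number a stronger inhibitor:
Compound 1, `COc1ccc(OC)c(NC(=O)CCCCCCNC(=O)C(O)(O)C(F)(F)F)c1`: 3870 nM
Compound 2, `COc1ccccc1NC(=O)CCCCCCNC(=O)C(O)(O)C(F)(F)F`: 10100 nM

Compound 2 stands highest of the two numbers, and its nearest neighbour is compound 1. Among the compounds with values here, the single measured step, a 2.6-fold higher number from compound 1 to compound 2 (0.42 log units; beyond the scatter), goes with hydrogen in place of methoxy on an aromatic carbon, so removing one methoxy weakened inhibition modestly.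

The next compound, compound 3, is `O=C(CCCCCCNC(=O)C(O)(O)C(F)(F)F)Nc1ccc(F)cc1`, to be measured in this assay. It differs from compound 2 by 4-fluorophenyl in place of 2-methoxyphenyl on an amide-type nitrogen. Within the data shown here, no measured pair shows this exact exchange. Among the measured compounds shown here, the only step that bears on it is a 2.6-fold higher number from compound 1 to compound 2 (0.42 log units; beyond the scatter), which shows that giving up a methoxy cost some potency. Compound 3 gives up the remaining methoxy as well and brings in a fluorine on a different aromatic position, so a further weakening of roughly that size, or no change beyond the scatter, is what is expected. The step expected is a 1.4-fold higher number from compound 2 to compound 3 (0.14 log units; within the scatter). For compound 3 the estimated value in this assay is 14000 nM, within a range from 5000 nM to 40000 nM.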

Compound 3, half-maximal inhibitory concentration: 7570 nM
Estimate against measurement, compound 3: 1.8-fold (0.27 log units) above; the measured number falls inside the stated range.
By their numbers in this assay, from the lowest: compounds 1, 3 and 2 (each within the scatter of the next, the first and the last beyond it).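

On the amide-type nitrogen, 4-fluorophenyl in place of 2-methoxyphenyl gives a 1.3-fold lower number from compound 2 to compound 3 (0.13 log units; within the scatter) in this assay, so compound 2 and compound 3 cannot be told apart in this read-out. The earlier step, a 2.6-fold higher number from compound 1 to compound 2 (0.42 log units; beyond the scatter), had tied a measurable difference to one methoxy on the ring, whereas this exchange, which also removes the hydrogen-bond acceptor counted on the 2-methoxyphenyl, leaves the two compounds level within the scatter, so at this stage the loss of that acceptor carries no measurable penalty when fluorine enters on the ring. No measurement offered here explains why the pair reads alike.

The exchange takes away the methoxy and brings in the fluorine in a single step, so the contribution of each stays unseparated, and a plain phenyl, a 4-methoxyphenyl or a 2-fluorophenyl cap would be needed to pull them apart. Also open, as far as these compounds go, is whether a larger change at this nitrogen, such as an amine or a carboxylic acid on the ring, or a longer chain in the linker, would move the number beyond the scatter.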